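Working notes on a three-compound aortic series

This account rests on a few compounds, and the source may have more. Where it says the series, first, only, none or still open, it means among the compounds named here.

In a functional assay on thoracic aorta (Rattus norvegicus, strain Wistar), with a stated time of 15 min (on this read-out higher numbers stand for an effect only at larger amounts of compound and lower numbers for an effect already at smaller amounts), compound 1 `CC(NC(=O)NS(=O)(=O)c1ccc(Cl)cc1)c1cc(Br)ccc1OCc1ccccc1` gives 57500 nM. Compound 2 `Cc1ccc(S(=O)(=O)NC(=O)NC(C)c2cc(Br)ccc2OCc2ccccc2)cc1` differs from compound 1 by methyl in place of chloro on an aromatic carbon and in this assay compound 2 gives 138000 nM; the step is a 2.4-fold higher number from compound 1 to compound 2 (0.38 log units; beyond the scatter). Compound 3 `CC(C)Oc1ccc(Br)cc1C(C)NC(=O)NS(=O)(=O)c1ccc(Cl)cc1` carries a different core, and the difference from compound 1 is isopropyl in place of benzyl on an oxygen on an aromatic ring. In this assay compound 3 gives 122000 nM, so that the step is a 2.1-fold higher number from compound 1 to compound 3 (0.33 log units; beyond the scatter). Compound 2 and compound 3 stand within the usual scatter of one another, and nothing more is said of that pair.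

Compound 4 `Cc1ccc(S(=O)(=O)NC(=O)NC(C)c2cc(Br)ccc2OC(C)C)cc1` has not yet been measured. It differs from compound 3 by methyl in place of chloro on an aromatic carbon. Going by the values given here, this is the same change as the one from compound 1 to compound 2, placed identically on the ring, and it occurs twice among the compounds here. Among the compounds with values here, the only measured precedent for it is a 2.4-fold higher number from compound 1 to compound 2 (0.38 log units; beyond the scatter), obtained on the other core. The expectation for compound 4 is a step of about a 2.3-fold higher number from compound 3 to compound 4 (0.36 log units; beyond the scatter) in this assay. That expectation rests on the size of a 2.4-fold higher number from compound 1 to compound 2 (0.38 log units; beyond the scatter). Within the data shown here, whether the change behaves alike on the core of compound 3 is not known, as only one instance has been measured. Compound 3 already stands at 122000 nM, a high number on this read-out, and compound 4 is expected to move further in the same direction. Compound 4 is estimated at 280000 nM in this assay, with a range from 130000 nM to 600000 nM.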

Compound 4, half-maximal effective concentration: 61800 nM
Beside the measured number, compound 4's estimate is 4.5-fold (0.66 log units) above it; measured number outside the range, below it.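

In this assay, methyl in place of chloro gives a 2.0-fold lower number from compound 3 to compound 4 (0.30 log units; within the scatter), and isopropyl in place of benzyl on the oxygen gives a 2.2-fold lower number from compound 2 to compound 4 (0.35 log units; beyond the scatter), so neither change keeps the size and direction it showed on the first pair. Neither change can therefore be carried from one core to the other as a fixed step among these compounds, and the effects of the two changes do not simply add: the same change on two cores in this assay, a 2.4-fold higher number (0.38 log units; beyond the scatter) from compound 1 to compound 2 and a 2.0-fold lower number (0.30 log units; within the scatter) from compound 3 to compound 4, 4.7-fold (0.68 log units) apart, beyond the scatter of two such steps. Going by these compounds alone, the second comparison uses the same four compounds read the other way, so it is not independent support, and with only two instances of each change the data do not show why the steps differ or how either change would behave on a further core: the same change on two cores in this assay, a 2.1-fold higher number (0.33 log units; beyond the scatter) from compound 1 to compound 3 and a 2.2-fold lower number (0.35 log units; beyond the scatter) from compound 2 to compound 4, 4.7-fold (0.68 log units) apart, beyond the scatter of two such steps.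

The compounds shown leave open whether the result for 4-chlorophenyl to 4-methylphenyl extends to other groups at that place, such as fluoro, methoxy or a carboxylic acid, and whether an ethyl group or a longer chain on the oxygen would follow benzyl or isopropyl. Also open, as far as these compounds go, is whether an amine or a nitrile in place of the bromo would shift the number on either core.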